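This account rests on a few compounds, and the source may have more. Where it says the series, first, only, none or still open, it means among the compounds named here.

Compound 1 `CC(C)OC(=O)N1CCC(Oc2cccc3c2CCN3c2ccc(S(C)(=O)=O)cc2)CC1` gives 70% in a functional assay on CHO-K1 cells with Glucose-dependent insulinotropic receptor (Homo sapiens) as the target, read by a luciferase reporter, with a stated time of 5 h (a lower number here means a smaller maximal response, a higher number a larger maximal response), the second highest of the three numbers measured. Compound 3 `CC(C)(C)OC(=O)N1CCC(Oc2cccc3c2CCN3c2ccc(S(C)(=O)=O)cc2)CC1` reaches 92%, while compound 2 `CC(C)(C)OC(=O)N1CCC(Oc2cccc3c2ccn3-c2ccc(S(C)(=O)=O)cc2)CC1` gives 28%. For the measured compounds named here, the only measured step between neighbours, a number 22 percentage points higher from compound 1 to compound 3 (beyond the scatter), concerns the saturated chain carbon bound to the oxygen next to the carbonyl group, a different part of the shared core. Compound 4 `CC(C)OC(=O)N1CCC(Oc2cccc3c2CCN3c2ccc(S(C)(=O)=O)cc2F)CC1` differs from compound 1 by fluoro in place of hydrogen on an aromatic carbon. Going by the values given here, no measured step touches this part of the molecule, so the numbers offer no direct guide, and a change no larger than the usual scatter is expected, no change at the digits printed from compound 1 to compound 4 (within the scatter). Compound 4 is therefore estimated at 70%, with a range from 50% to 90% in this assay.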

Compound 4, largest response reached (reported as percent of maximum), in percent of the reference or control that the assay uses: 62%
Beside the measured number, compound 4's estimate is 8 percentage points above it; the range from low to high includes it.
By their numbers in this assay, from the lowest: compound 2; then compounds 4 and 1 (each within the scatter of the next); then compound 3.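

In this assay, fluoro in place of hydrogen on this aromatic carbon gives a number 8 percentage points lower from compound 1 to compound 4 (within the scatter) and so adds a first measured result for this part of the molecule. A single fluoro here, ortho to a large group, produces no change that can be told apart from ordinary repeat variation. No measurement available here offers an explanation for this result. Going by these compounds, whether chloro, methoxy or an amine on the same carbon would give a similar maximal response remains open, as does the effect of fluoro at other carbons of this ring.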